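A few compounds are considered here, and "the series" means these few. Any claim that something is new, unique, unknown or untested is made for them only; others in the source may bear on it.

Compound 1 `C=C1C(=O)[C@]23C[C@@]1(Cl)CC[C@H]2[C@@]12C=CC(=O)[C@](C)(C(=O)O1)[C@H]2[C@@H]3C(=O)OC` gives 39800 nM
Compound 2 `C=C1C(=O)[C@]23C[C@@]1(F)CC[C@H]2[C@@]12C=CC(=O)[C@](C)(C(=O)O1)[C@H]2[C@@H]3C(=O)OC` gives 40600 nM
Compound 3 `C=C1C(=O)[C@]23C[C@@]1(F)CC[C@H]2[C@@]12C=CC(=O)[C@](C)(C(=O)O1)[C@H]2[C@@H]3C(=O)OCc1ccccc1` gives 44100 nM

Going by the values given here, all three values come from a functional assay on HepG2 cells (Homo sapiens) for cytotoxicity, read by MTT assay (a lower number here means a stronger inhibitor, a higher number a weaker inhibitor), and compound 2 sits within the scatter of the other two, so the series so far forms one level. Compound 4 `C=C1C(=O)[C@]23C[C@@]1(OCC)CC[C@H]2[C@@]12C=CC(=O)[C@](C)(C(=O)O1)[C@H]2[C@@H]3C(=O)OC` carries ethoxy in place of fluoro on a saturated ring carbon. The step of a 1.0-fold higher number from compound 1 to compound 2 (0.01 log units; within the scatter) alters the same ring carbon and the step of a 1.1-fold higher number from compound 2 to compound 3 (0.04 log units; within the scatter) alters another place, and both lie within the scatter. Neither brings in a group like ethoxy, so the evidence is thin, and no step beyond the scatter is expected in this assay for this change. Compound 4 is estimated at 42000 nM (range 20000 nM to 85000 nM). This estimate means a 1.0-fold higher number from compound 2 to compound 4 (0.01 log units; within the scatter) as the expected step.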

Compound 4, half-maximal inhibitory concentration: 120000 nM
Estimate against measurement, compound 4: 2.9-fold (0.46 log units) below; measured number above the stated range.
By their numbers in this assay, from the lowest: compounds 1, 2 and 3 (each within the scatter of the next); then compound 4.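

In this assay, going by these compounds alone, ethoxy on the saturated ring carbon gives the only steps beyond the scatter: a 3.0-fold higher number from compound 2 to compound 4 (0.47 log units; beyond the scatter) and a 3.0-fold higher number from compound 1 to compound 4 (0.48 log units; beyond the scatter). The exchange of chloro for fluoro on the same carbon, a 1.0-fold higher number from compound 1 to compound 2 (0.01 log units; within the scatter), had left the number within the scatter, so this position tolerates that halogen exchange but is not indifferent to every group. Nothing here accounts for the weakening with ethoxy. Open, on these data alone, is whether a hydroxyl, an amine or a longer alkoxy chain on this carbon would shift the number as ethoxy does.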